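A few compounds are considered here, and "the series" means these few. Any claim that something is new, unique, unknown or untested is made for them only; others in the source may bear on it.

Measured in an ADME assay on MDBK cells (Bos taurus) for cytotoxicity, read by MTT assay, with a stated time of 72 h; a lower number here means that less compound is tolerated, a higher number that more compound is tolerated:
- compound 1 `Brc1ccc(NCc2cn(-c3ccccc3)nc2-c2ccccc2)cc1` gives > 100000 nM
- compound 2 `Cc1ccc(NCc2cn(-c3ccccc3)nc2-c2ccc(Cl)cc2)cc1` gives > 100000 nM
- compound 3 `FC(F)(F)c1ccc(NCc2cn(-c3ccccc3)nc2-c2ccc(Br)cc2)cc1` gives 46000 nM

Compound 2 has no exact number on this read-out. It stands at the limit of > 100000 nM in this assay, at which 2 of the 3 values shown sit, and shares that position with compound 1. Of the three, only compound 3 gives a number rather than a limit.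

The next compound to be measured is compound 4 `Cc1ccc(NCc2cn(-c3ccccc3)nc2-c2ccc(C)cc2)cc1`. It differs from compound 2 by methyl in place of chloro on an aromatic carbon, para to a large group (methyl in place of chloro on an aromatic carbon), so that 4-chlorophenyl becomes 4-methylphenyl. Going by the values given here, no measured pair shows this exchange. The expectation therefore rests on compound 2, which gives > 100000 nM as a limit of the assay.

In this assay no step beyond the scatter is expected, in either direction. The expected change is small (a number no higher from compound 2 to compound 4 (the limit leaves the size open)), and a further report of a limit is the likeliest outcome. For compound 4 the estimated half-maximal cytotoxic concentration is 100000 nM (expected range 50000 nM to 200000 nM) and remains to be tested.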

Compound 4, half-maximal cytotoxic concentration: > 100000 nM
Compound 4 ended at the assay's limit; the forecaster's own chance of this, stated with the estimate: 75%; the middle value sits exactly at the limit.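

Neither compound 2 nor compound 4 gives a number in this assay, so no step can be read for methyl in place of chloro, and each value is a limit: the limit of > 100000 nM in this assay, at which 3 of the 4 values shown sit. The compounds shown leave open whether this exchange changes the tolerated concentration at all.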